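A few compounds are considered here, and "the series" means these few. Any claim that something is new, unique, unknown or untested is made for them only; others in the source may bear on it.

In a functional assay on ECa-109 cells for inhibition, with ECa-109 cell line (Homo sapiens) as the target, read by sulforhodamine B assay (on this read-out lower numbers stand for stronger inhibition and higher numbers for weaker inhibition), compound 1 (`CCc1ccc(NC2=CC(=O)c3c(nc4n3[C@H]3OC[C@@H](O)[C@H]3OC4)C2=O)cc1`) gives > 4000 nM, which is a limit of the assay and not a number. Compound 2 (`CCOc1ccc(NC2=CC(=O)c3c(nc4n3[C@H]3OC[C@@H](O)[C@H]3OC4)C2=O)cc1`) gives > 4000 nM, likewise a limit, so its position on the scale is bounded on one side only. The evidence so far amounts to the limit of > 4000 nM in this assay, at which 2 of the 2 values shown sit. For the measured compounds named here, the single measured step is a step that the two limits leave unreadable from compound 1 to compound 2, and it offers no size to carry forward. Compound 3 (`O=C1C(NCc2ccccc2)=CC(=O)c2c1nc1n2[C@H]2OC[C@@H](O)[C@H]2OC1`) has benzyl in place of 4-ethoxyphenyl on an amine nitrogen. With no readable step to draw on, no particular size or direction of change is expected in this assay, and the expectation stays close to the limit. The expected outcome, held only loosely, is a step that the limit leaves unreadable from compound 2 to compound 3. For compound 3 the estimated value is 5000 nM, within an expected range of 1800 nM to 14000 nM.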

Compound 3, half-maximal inhibitory concentration: > 8000 nM
Compound 3 gave a limit, no number; the forecaster's own chance of this, stated with the estimate: 65%; middle value at least 1.6-fold (0.20 log units) from the limit.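

For the compounds shown here, compound 3 gives > 8000 nM in this assay, which is a limit of the assay and not a number, so no step from compound 1 or compound 2 to compound 3 can be read. The compounds shown leave open whether benzyl, 4-ethoxyphenyl or 4-ethylphenyl on the amine nitrogen makes any difference in this assay.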